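Iodo for phenyl on the shared core: cytotoxicity notes

The source may hold more compounds than are shown below. What is called first, only, known or untested is meant among the compounds shown, and "the series" means these compounds.

Measured compounds:
compound 1: `Cc1cc(-c2ccccc2)cn2c(CSCCc3ccccc3)cnc12`, 20 ug/mL
compound 2: `Cc1cc(-c2cccs2)c2ncc(CSCCc3ccccc3)n2c1`, 100 ug/mL

In an ADME assay on HEL cells (Homo sapiens) for cytotoxicity, with a stated time of 3 days (on this read-out lower numbers stand for higher toxicity in this test and higher numbers for lower toxicity in this test), compound 1 gives 20 ug/mL and compound 2 gives 100 ug/mL. Compound 1 stands lowest of the two numbers; the number for compound 2 is higher by a margin beyond the usual scatter, so compound 1 is the more toxic of the two in this test. Among the measured compounds shown here, compound 2 differs from compound 1 in more than one place and no single step between measured compounds exists, so nothing ties the gap between them to any one change.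

Compound 3, `Cc1cc(I)cn2c(CSCCc3ccccc3)cnc12`, has not yet been measured. It differs from compound 1 in one place: iodo in place of phenyl on an aromatic carbon. A ring is removed and a single heavy atom stands in its place; the rest of the molecule is unchanged.

For the measured compounds named here, with no measured step to lean on, the direction is open. The step from compound 1 to compound 3 is expected to be modest, a 2.0-fold higher number from compound 1 to compound 3 (0.30 log units; within the scatter), within or just beyond the scatter, toward a higher number. Compound 3 is estimated at 40 ug/mL, with a range from 10 ug/mL to 100 ug/mL. The range is wide, and a reported limit rather than a number cannot be ruled out.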

Compound 3, minimum cytotoxic concentration: >= 0.8 ug/mL
Compound 3: only a limit was reported (the forecaster's own chance of this, stated with the estimate: 20%); the middle value lies beyond the limit too.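

In this assay compound 3 gives >= 0.8 ug/mL, which is a limit and not a number. The step from compound 1 to compound 3 therefore cannot be read. The compounds shown leave open whether iodo in place of phenyl on the shared core raises or lowers the number, and by how much.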